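Adding phenylsulfonyl to the amine nitrogen of compound 2

The compounds below may be only part of what the source reports. "The series", "measured", "known", "first", "only" and "open" are said of these compounds alone.

Series notes. In an ADME assay on WI-38 cells (Homo sapiens) for cytotoxicity, read by sulforhodamine B assay, with a stated time of 24 h (a higher number here means a weaker inhibitor, a lower number a stronger inhibitor), compound 2 (`N/N=C1\C(=O)Nc2ccc(S(=O)(=O)N3CCOCC3)cc21`) gives 391000 nM and compound 1 (`Cc1ccc(/N=C2\C(=O)Nc3ccc(S(=O)(=O)N4CCOCC4)cc32)cc1`) gives 309000 nM. Compound 2 therefore has no measured neighbour outside the scatter, and the two values cannot be ordered.

The next entry is compound 3 (`O=C1Nc2ccc(S(=O)(=O)N3CCOCC3)cc2/C1=N/NS(=O)(=O)c1ccccc1`), with phenylsulfonyl in place of hydrogen on an amine nitrogen. The counted change is phenylsulfonyl in place of hydrogen on an amine nitrogen.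

Going by the values given here, one measured step bears on this: a 1.3-fold higher number from compound 1 to compound 2 (0.10 log units; within the scatter). That step swaps 4-methylphenyl for amino on a double-bonded nitrogen, so it concerns the same part of the structure and shows that a substituent carrying an aromatic ring can be exchanged there with no change beyond the scatter in this assay. Among the compounds with values here, no measured compound carries a sulfonyl group at this site, so the support is thin. No step beyond the scatter is expected, with at most a slight lean toward a lower number.

The expected step is a 1.6-fold lower number from compound 2 to compound 3 (0.19 log units; within the scatter). For compound 3 the estimated value is 250000 nM, with an expected range of 90000 nM to 500000 nM.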

Compound 3, half-maximal inhibitory concentration: 302000 nM
Compound 3: middle estimate off by 1.2-fold (0.08 log units), on the low side; the measured number falls inside the stated range.
By their numbers in this assay, from the lowest: compounds 3, 1 and 2 (each within the scatter of the next).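

In this assay the step from hydrogen to phenylsulfonyl on the amine nitrogen reads as (a 1.3-fold lower number from compound 2 to compound 3 (0.11 log units; within the scatter)), and the exchange of 4-methylphenyl for (phenylsulfonyl)amino on the double-bonded nitrogen reads as (a 1.0-fold lower number from compound 1 to compound 3 (0.01 log units; within the scatter)). The earlier pair covered only amino and 4-methylphenyl at this site, whereas compound 3 adds a sulfonyl-linked aromatic ring, and the three groups still cannot be told apart in this assay on the shared core. No measurement on hand accounts for this result.

On these data alone, whether any group on this nitrogen moves the number beyond the scatter remains open, for example a carboxylic acid, a basic amine or a longer alkyl chain. Also open, as far as these compounds go, is whether the aromatic ring of the phenylsulfonyl group matters at all, which a methylsulfonyl group or a chloro-substituted phenylsulfonyl group in its place would begin to address.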